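Trifluoromethyl in place of methoxy: notes on compound 4

The source may report more compounds than this note shows. Statements on the series, on what has been measured and on what is new or still open speak of the compounds shown alone.

In a functional assay on SK-OV-3 cells (Homo sapiens) for antiproliferative activity, read by MTT assay, with a stated time of 72 h (on this read-out lower numbers stand for stronger inhibition and higher numbers for weaker inhibition), compound 1 `O=C(CCc1cccc2c1B(O)OC2)Nc1cccc(I)c1` gives 630 nM and compound 2 `O=C(CCc1cccc2c1B(O)OC2)Nc1cccc(-c2ccc(Cl)cc2)c1` gives 220 nM, while compound 3 `COc1ccc(-c2cccc(NC(=O)CCc3cccc4c3B(O)OC4)c2)cc1` gives 48 nM, the lowest of the three numbers. Compound 4 `O=C(CCc1cccc2c1B(O)OC2)Nc1cccc(-c2ccc(C(F)(F)F)cc2)c1` carries trifluoromethyl in place of methoxy on an aromatic carbon, para to a large group (trifluoromethyl in place of methoxy on an aromatic carbon). Two steps start from the iodo compound: 4-chlorophenyl in place of iodo gives a modest step (a 2.9-fold lower number from compound 1 to compound 2 (0.46 log units; beyond the scatter)) and 4-methoxyphenyl in place of iodo gives a large one (a 13-fold lower number from compound 1 to compound 3 (1.12 log units; beyond the scatter)). The step nearest to the change at hand is methoxy in place of chloro, which is modest and beyond the scatter (a 4.6-fold lower number from compound 2 to compound 3 (0.66 log units; beyond the scatter)). Within the data shown here, no trifluoromethyl compound has been measured, so the methoxy compound is the only low point, and losing methoxy may give back that gain. For compound 4 a higher number is therefore expected, with the estimated step of a 4.0-fold higher number from compound 3 to compound 4 (0.60 log units; beyond the scatter) of modest size. The expected value for compound 4 is 190 nM, with an estimated range from 70 nM to 500 nM as a working expectation.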

Compound 4, half-maximal inhibitory concentration: 500 nM
Estimate against measurement, compound 4: 2.6-fold (0.42 log units) below, and the stated range covers the measured number.
By their numbers in this assay, from the lowest: compound 3; then compound 2; then compounds 4 and 1 (each within the scatter of the next).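

In this assay trifluoromethyl in place of methoxy gives a 10-fold higher number from compound 3 to compound 4 (1.02 log units; beyond the scatter) and so removes the whole gain that the 4-methoxyphenyl group showed over iodo. Trifluoromethyl in place of chloro gives a 2.3-fold higher number from compound 2 to compound 4 (0.36 log units; beyond the scatter) as a further rise, which places the three groups at this position in the order methoxy, chloro, trifluoromethyl, from lowest number to highest. An added phenyl ring alone therefore brings no gain: 4-(trifluoromethyl)phenyl in place of iodo gives a 1.3-fold lower number from compound 1 to compound 4 (0.10 log units; within the scatter) and leaves compound 4 within the scatter of compound 1, so the gain depends on the group the ring carries. Nothing at hand bears on the cause of this order.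

Open, from the compounds shown here alone, is whether an ethoxy, a hydroxyl or an amine at this position would keep the low number of compound 3. Also open, going by these compounds, is whether the order of the three groups holds in any other cell line.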